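The compounds below may be only part of what the source reports. "The series", "measured", "known", "first", "only" and "open" are said of these compounds alone.

Measured in an ADME assay on BHK-21 cells (Mesocricetus auratus) for cytotoxicity, read by MTT assay, with a stated time of 72 h; a lower number here means that less compound is tolerated, a higher number that more compound is tolerated:
- compound 1 `FC(F)(F)c1ccc(-c2nn(-c3ccccc3)cc2CNc2ccc(Cl)cc2)cc1` gives 31000 nM
- compound 2 `FC(F)(F)c1ccc(NCc2cn(-c3ccccc3)nc2-c2ccc(C(F)(F)F)cc2)cc1` gives 27000 nM
- compound 3 `Clc1ccc(NCc2cn(-c3ccccc3)nc2-c2ccc(Cl)cc2)cc1` gives 73000 nM

In this assay, compound 2 sits at the low end of these numbers, level within the scatter with compound 1, while the value of compound 3 stands higher than both.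

Compound 4 `Cc1ccc(-c2nn(-c3ccccc3)cc2CNc2ccc(C(F)(F)F)cc2)cc1` is compound 2 with methyl in place of trifluoromethyl on an aromatic carbon, para to a large group (methyl in place of trifluoromethyl on an aromatic carbon). Within the data shown here, no measured step brings in methyl, so only the two steps that exchange trifluoromethyl and chloro bear on it. One step replaces trifluoromethyl with chloro and is modest, a 2.4-fold higher number from compound 1 to compound 3 (0.37 log units; beyond the scatter). The other replaces chloro with trifluoromethyl and shows a 1.1-fold lower number from compound 1 to compound 2 (0.06 log units; within the scatter). With only the first as a guide, a small rise in this assay is expected, probably not clearly beyond the scatter. The expected change is a 1.7-fold higher number from compound 2 to compound 4 (0.22 log units; within the scatter). For compound 4 the estimated value is 45000 nM, with an expected range of 20000 nM to 100000 nM.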

Compound 4, half-maximal cytotoxic concentration: 88000 nM
Estimate against measurement, compound 4: 2.0-fold (0.29 log units) below; measured number inside the range.
By their numbers in this assay, from the lowest: compounds 2 and 1 (each within the scatter of the next); then compounds 3 and 4 (each within the scatter of the next).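

The change from 4-(trifluoromethyl)phenyl to 4-methylphenyl gives, in this assay, a 3.3-fold higher number from compound 2 to compound 4 (0.51 log units; beyond the scatter). Among these compounds, this is the first sign that a carbon-only methyl group at this position can carry the rise, so a halogen is not needed there. The earlier replacement of trifluoromethyl at the same place, by chloro, gave a 2.4-fold higher number from compound 1 to compound 3 (0.37 log units; beyond the scatter); with the new step, both replacements shown raise the number beyond the scatter, though they occur with different groups on the other aromatic ring. No measurement shown here explains the rise.

As far as these compounds go, it remains open whether a methoxy group, an amine or a carboxylic acid at this position would follow the same direction. Also open, from the compounds shown here alone, is whether methyl would give a similar step with chloro on the other ring.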